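Methylsulfanyl for Methyl: Predicting Compound 3

This account rests on a few compounds, and the source may have more. Where it says the series, first, only, none or still open, it means among the compounds named here.

Compound 1 `COc1cc(-n2ncnc2-c2ccc(C)cc2)cc(OC)c1OC` was tested in a functional assay on HL-60 cells (Homo sapiens) for antiproliferative activity, read by MTT assay, with a stated time of 72 h (a higher number here means a weaker inhibitor, a lower number a stronger inhibitor), and gave 90 nM, the higher of the two numbers recorded so far and therefore the weaker of the two. Compound 2 `CCOc1ccc(-c2ncnn2-c2cc(OC)c(OC)c(OC)c2)cc1Cl` gave 3 nM in this assay, a gap beyond the usual scatter. Compound 3 `COc1cc(-n2ncnc2-c2ccc(SC)cc2)cc(OC)c1OC` differs from compound 1 in one place: methylsulfanyl in place of methyl on an aromatic carbon. Within the data shown here, no measured pair shows this particular change, so its effect is unknown; a small shift toward a lower number, or none beyond the scatter, is expected. The estimated value for compound 3 in this assay is 60 nM, within 15 nM to 250 nM, the expected step being a 1.5-fold lower number from compound 1 to compound 3 (0.18 log units; within the scatter).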

Compound 3, half-maximal inhibitory concentration: 500 nM
Estimate against measurement, compound 3: 8.3-fold (0.92 log units) below; measured number above the stated range.
By their numbers in this assay, from the lowest: compound 2; then compound 1; then compound 3.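

Swapping methyl for methylsulfanyl at this place, para to a large group, gives a 5.6-fold higher number from compound 1 to compound 3 (0.74 log units; beyond the scatter) in this assay. The step runs toward weaker inhibition, so this position does not treat these two small groups alike: one added sulfur atom is enough to separate them beyond the usual scatter. No measured evidence here accounts for the loss.

On these data alone, how an amine, a hydroxyl or a trifluoromethyl would compare with methyl at this same carbon remains open. So does whether this swap would give a similar step on another core.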